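Compound 2 and the 2-chlorophenyl exchange

A few compounds are considered here, and "the series" means these few. Any claim that something is new, unique, unknown or untested is made for them only; others in the source may bear on it.

In a functional assay on DU-145 cells (Homo sapiens) for inhibition, read by MTT assay, with a stated time of 72 h (a higher number here means a weaker inhibitor, a lower number a stronger inhibitor), compound 1 (`O=C1C=C(N2CCN(c3ccccc3Cl)CC2)C(=O)c2ccccc21`) gives 2900 nM and compound 2 (`O=C1C=C(N2CCN(c3ccc(F)cc3)CC2)C(=O)c2c(O)cccc21`) gives 8400 nM as the higher of the two numbers. Compound 2 is thus the weaker inhibitor of the pair, with the gap beyond the scatter. Going by the values given here, no step between measured compounds that differ in one place is available. Compound 3 (`O=C1C=C(N2CCN(c3ccccc3Cl)CC2)C(=O)c2c(O)cccc21`) keeps the core of compound 2 and takes 2-chlorophenyl in place of 4-fluorophenyl on an amine nitrogen in a ring. Among the compounds with values here, compound 1 also carries 2-chlorophenyl and gives 2900 nM as the only guide. A moderate move toward a lower number is therefore expected in this assay, with an estimated 2.1-fold lower number from compound 2 to compound 3 (0.32 log units; beyond the scatter) that may not clear the scatter by much. For compound 3 the estimate is 4000 nM with an expected range from 1500 nM to 10000 nM in this series.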

Compound 3, half-maximal inhibitory concentration: 2300 nM
Compound 3: middle estimate off by 1.7-fold (0.24 log units), on the high side, within the range that was stated.
By their numbers in this assay, from the lowest: compounds 3 and 1 (each within the scatter of the next); then compound 2.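

In this assay, going by these compounds alone, the exchange to 2-chlorophenyl in place of 4-fluorophenyl on the amine nitrogen in a ring gives a 3.7-fold lower number from compound 2 to compound 3 (0.56 log units; beyond the scatter), the first one-place reading at this position, and it lies beyond the scatter. Hydroxy in place of hydrogen on an aromatic carbon gives a 1.3-fold lower number from compound 1 to compound 3 (0.10 log units; within the scatter), so with 2-chlorophenyl held constant this change does not separate the two compounds. Nothing measured here accounts for either reading.

The 2-chlorophenyl exchange alters both the halogen and its place on the phenyl ring, so the contribution of each stays unresolved; 4-chlorophenyl and 2-fluorophenyl on the same nitrogen would part them. As far as these compounds go, how an unsubstituted phenyl at this position, or methoxy in place of the hydroxy, would read also remains open.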